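Anilino group swapped on a shared core: cytotoxicity outlook

The compounds below may be only part of what the source reports. "The series", "measured", "known", "first", "only" and "open" are said of these compounds alone.

Compound 1 `CCCCCCNc1nc(SCc2ccc(C(F)(F)F)cc2)nc2ccccc12`: 24300 nM
Compound 2 `Cc1ccccc1Nc1nc(SCc2ccc(C(F)(F)F)cc2)nc2ccccc12`: 37500 nM
Compound 3 `FC(F)(F)c1ccc(CSc2nc(Nc3ccc(Cl)cc3)c3ccccc3n2)cc1`: not yet measured

Among the compounds with values here, in a functional assay on MCF7 cells (Homo sapiens) for cytotoxicity, read by MTT assay, with a stated time of 72 h (on this read-out higher numbers stand for weaker inhibition and lower numbers for stronger inhibition), compound 2 gives 37500 nM and compound 1 gives 24300 nM; the two sit within the scatter of each other, since a 1.5-fold higher number from compound 1 to compound 2 (0.19 log units; within the scatter) is the only measured step and it does not exceed the scatter. Compound 3 differs from compound 2 by 4-chlorophenyl in place of 2-methylphenyl on a nitrogen on an aromatic ring. Within the data shown here, the one measured step, a 1.5-fold higher number from compound 1 to compound 2 (0.19 log units; within the scatter), replaced a chain on that nitrogen with an aromatic ring and changed little; no measured pair compares two different aromatic rings at this position, so there is no direct precedent. Only a small step, within the scatter, is therefore expected for compound 3 in this assay, with no clear direction, and the expected change from compound 2 is a 1.3-fold lower number from compound 2 to compound 3 (0.10 log units; within the scatter). Compound 3 is estimated at 30000 nM, within the range 10000 nM to 90000 nM.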

Compound 3, half-maximal inhibitory concentration: 21500 nM
Compound 3: middle estimate off by 1.4-fold (0.14 log units), on the high side; the measured number falls inside the stated range.
By their numbers in this assay, from the lowest: compounds 3, 1 and 2 (each within the scatter of the next).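

In this assay this position now has its first comparison of two aromatic rings, 4-chlorophenyl in place of 2-methylphenyl (a 1.7-fold lower number from compound 2 to compound 3 (0.24 log units; within the scatter)). Setting the same 4-chlorophenyl in place of the hexyl chain gives a similar picture (a 1.1-fold lower number from compound 1 to compound 3 (0.05 log units; within the scatter)), so the chain and both rings on this nitrogen read alike within the scatter. No measurement that could explain this is at hand.

The compounds shown leave open whether a different kind of group on this nitrogen, such as a chain ending in an amine or a carboxylic acid, would move the number beyond the scatter. They also cannot separate the effect of swapping methyl for chlorine from that of moving the group around the ring, since the two rings differ in both.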